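Swapping the hydroxy-acid headgroup for a fluoro-acid in a mGlu2 modulator

A few compounds are considered here, and "the series" means these few. Any claim that something is new, unique, unknown or untested is made for them only; others in the source may bear on it.

Three compounds from one study were tested in an assay on HEK293 cells for positive allosteric modulation of metabotropic glutamate receptor 2 (Rattus norvegicus), read by thallium flux; on this read-out higher numbers stand for larger maximal responses and lower numbers for smaller maximal responses. Compound 1, `O=C(O)c1cc(-c2cccc(COc3ccc4c(c3)CN(C3CCCC3)C4=O)c2)ccc1O`, gives 90.1% in this assay. Compound 3, `O=C(O)c1cc(-c2cccc(-c3ccc4c(c3)CN(C3CCCC3)C4=O)c2)ccc1Cl`, gives 85.8%, and compound 2, `Cn1sc2cc(OCc3cccc(-c4ccc(Cl)c(C(=O)O)c4)c3)ccc2c1=O`, gives 74.7%. Compound 1 therefore stands at the top of the three numbers, but its gap to compound 3 is within the usual scatter of repeated measurements, and only the gap to compound 2 lies beyond it. No pair among these three differs in a single place, so no step between measured compounds can be read directly.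

Compound 4, `O=C(O)c1cc(F)cc(-c2cccc(COc3ccc4c(c3)CN(C3CCCC3)C4=O)c2)c1`, is not yet measured. It differs from compound 1 in one place: 3-carboxy-5-fluorophenyl in place of 3-carboxy-4-hydroxyphenyl on an aromatic carbon. The change keeps the carboxylic acid but removes the hydroxyl and adds a fluorine on the same ring.

Going by the values given here, with no measured step of this kind available, a modest change is expected rather than a large one, and the direction is judged downward on the grounds that the three measured numbers cluster near the upper range. Compound 4 is expected to give 80% in this assay, within 62% to 98%. That estimate means a step of a number 10.1 percentage points lower from compound 1 to compound 4 (beyond the scatter), expected to be small and close to the scatter.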

Compound 4, largest response reached (reported as percent of maximum), in percent of the reference or control that the assay uses: 80.8%
Compound 4: middle estimate off by 0.8 percentage points, on the low side; the measured number falls inside the stated range.
By their numbers in this assay, from the lowest: compounds 2, 4, 3 and 1 (each within the scatter of the next, the first and the last beyond it).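

Going by these compounds alone, at this position, the one step that can be read is in this assay, where 3-carboxy-5-fluorophenyl in place of 3-carboxy-4-hydroxyphenyl on an aromatic carbon gives a number 9.3 percentage points lower from compound 1 to compound 4 (within the scatter), the first direct comparison at this position, since the earlier compounds offered no pair differing in one place. On this single step, the hydroxyl can leave the ring and a fluorine can enter it, with the carboxylic acid kept, without a difference in maximal response that stands clear of the usual scatter of repeated measurements, although this holds only for the core of compound 1. Nothing given here explains this result.

The hydroxyl leaves and the fluorine enters in one change, so a plain 3-carboxyphenyl group would be needed to tell the two apart, and the contribution of each remains unresolved. Both groups also carry the carboxylic acid, which leaves open how the maximal response would stand with a tetrazole or a primary amide in its place on this ring.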